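A few compounds are considered here, and "the series" means these few. Any claim that something is new, unique, unknown or untested is made for them only; others in the source may bear on it.

For the measured compounds named here, compound 1 `Cc1ccc(-c2csc(=N)n2CC(=O)N2CCN(c3ccccc3)CC2)cc1` is one of three compounds measured in an assay on isolated protein for inhibition of Thymidylate synthase (Homo sapiens); on this read-out lower numbers stand for stronger inhibition and higher numbers for weaker inhibition. In this assay compound 1 gives 5600 nM. Its nearest neighbour is compound 2 `Cc1ccc(-c2csc(=N)n2CC(=O)N2CCN(C)CC2)cc1`, which gives 19300 nM, so that the step of a 3.4-fold higher number from compound 1 to compound 2 (0.54 log units; beyond the scatter) arises from methyl in place of phenyl on an amine nitrogen in a ring. The furthest is compound 3 `CN1CCN(C(=O)Cn2c(-c3ccccc3)csc2=N)CC1`, which gives 1140 nM; the step of a 17-fold lower number from compound 2 to compound 3 (1.23 log units; beyond the scatter) comes from hydrogen in place of methyl on an aromatic carbon.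

Compound 4 `N=c1scc(-c2ccc(Cl)cc2)n1CC(=O)N1CCN(c2ccccc2)CC1` has not yet been measured in this assay. It differs from compound 1 by chloro in place of methyl on an aromatic carbon, para to a large group, or read one bond further out, 4-methylphenyl to 4-chlorophenyl. Going by the values given here, no measured step swaps methyl for chloro. Among the compounds with values here, the only step touching this position is the one from compound 2 to compound 3, where losing the methyl gave a large gain, which suggests the position tolerates change and that the methyl is not helpful. A chloro in its place is therefore expected to give a modest lower number, a 2.0-fold lower number from compound 1 to compound 4 (0.30 log units; within the scatter), though with wide uncertainty. Compound 4 is estimated at 2800 nM, in the range 900 nM to 9000 nM.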

Compound 4, inhibition constant: 5090 nM
Compound 4: the middle estimate sits 1.8-fold (0.26 log units) below what was measured, and the stated range covers the measured number.
By their numbers in this assay, from the lowest: compound 3; then compounds 4 and 1 (each within the scatter of the next); then compound 2.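

In this assay, putting chloro in place of methyl on the aromatic carbon gives a 1.1-fold lower number from compound 1 to compound 4 (0.04 log units; within the scatter), so on the core of compound 1 the two groups cannot be told apart at this position. The earlier compounds shown here showed this position only through the loss of the methyl, in a 17-fold lower number from compound 2 to compound 3 (1.23 log units; beyond the scatter), a step taken with methyl rather than phenyl on the ring amine nitrogen; the new step adds that a change here need not shift the number, at least when chloro replaces methyl with that phenyl in place. Nothing available bears on why methyl and chloro read alike here.

The compounds shown leave open whether hydrogen in place of methyl would bring the same large step with the phenyl on the ring amine nitrogen, or whether that step belongs only to the compounds with methyl on that nitrogen. They also leave open how a methoxy group, an amine or a carboxylic acid would read on the same aromatic carbon, since only hydrogen, methyl and chloro appear there.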